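Chloro in Place of Amino in Compound 2

The source may report more compounds than this note shows. Statements on the series, on what has been measured and on what is new or still open speak of the compounds shown alone.

In a functional assay on CEM-SS cells (Homo sapiens) for cytotoxicity (on this read-out higher numbers stand for weaker inhibition and lower numbers for stronger inhibition), compound 1 `Nc1nc2cc(Cl)c(Cl)cc2n1Cc1cccc(C(F)(F)F)c1` gives 34000 nM and compound 2 `Nc1nc2cc(Cl)c(Cl)cc2n1Cc1cccc([N+](=O)[O-])c1` gives 47000 nM, so the two stand within the scatter of each other. Compound 3 `O=[N+]([O-])c1cccc(Cn2c(Cl)nc3cc(Cl)c(Cl)cc32)c1` differs from compound 2 by chloro in place of amino on an aromatic carbon, between two ring nitrogen atoms (chloro in place of amino on an aromatic carbon). For the measured compounds named here, the only measured step, a 1.4-fold higher number from compound 1 to compound 2 (0.14 log units; within the scatter), is nitro in place of trifluoromethyl and leaves the amino group untouched. It offers no direct guide to this change, and no step beyond the scatter is expected. The expected step is a 1.2-fold lower number from compound 2 to compound 3 (0.07 log units; within the scatter). Compound 3 is estimated at 40000 nM, within an expected range of 12000 nM to 110000 nM.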

Compound 3, half-maximal inhibitory concentration: > 100000 nM
Compound 3 ended at the assay's limit; the forecaster's own chance of this, stated with the estimate: 25%; middle value at least 2.5-fold (0.39 log units) from the limit.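

Chloro in place of amino on this aromatic carbon, between two ring nitrogen atoms, gives an at least 2.1-fold higher number from compound 2 to compound 3 (0.32 log units; beyond the scatter) in this assay, the only step shown that lies beyond the scatter. For the compounds shown here, the earlier step left the amino group untouched, so this is the first sign that the read-out responds to a change at this position. The value of compound 3 is a limit of the assay and not a number, so the full size of the step stays unknown: the limit of > 100000 nM in this assay, at which 1 of the 3 values shown sits.

As far as these compounds go, whether a methyl group or a hydroxyl group at this carbon would behave like chloro or like amino remains open. So does whether the same change would give a similar step with trifluoromethyl in place of nitro.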